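Ethoxy to pyrrolidinyl on the acylguanidine sulfone core

The source may report more compounds than this note shows. Statements on the series, on what has been measured and on what is new or still open speak of the compounds shown alone.

Compound 2 `CCOc1cc(C)c(C(=O)N=C(N)N)cc1S(C)(=O)=O` gives 19 nM in a functional assay for inhibition of sodium/hydrogen exchanger (Oryctolagus cuniculus) (a lower number here means a stronger inhibitor, a higher number a weaker inhibitor), the lowest of the two numbers measured. Compound 1 `Cc1cc(OCc2ccccc2)c(S(C)(=O)=O)cc1C(=O)N=C(N)N` gives 28 nM and is the nearest; the step of a 1.5-fold lower number from compound 1 to compound 2 (0.17 log units; within the scatter) stays within the scatter, so the two compounds cannot be ordered. Compound 3 `Cc1cc(N2CCCC2)c(S(C)(=O)=O)cc1C(=O)N=C(N)N` is not yet measured. It differs from compound 2 by pyrrolidin-1-yl in place of ethoxy on an aromatic carbon. Among the measured compounds shown here, the only measured step, from compound 1 to compound 2, changes what sits on a saturated chain carbon bound to an oxygen on an aromatic ring and keeps the oxygen; compound 3 removes the ethoxy altogether, a change of a different kind, so no measured step maps onto it directly. The measured step moved little, and nothing here argues for a large shift either way, so compound 3 is expected to give 30 nM, within 8 nM to 110 nM, a step of a 1.6-fold higher number from compound 2 to compound 3 (0.20 log units; within the scatter) that is estimated with wide uncertainty.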

Compound 3, half-maximal inhibitory concentration: 11 nM
Beside the measured number, compound 3's estimate is 2.7-fold (0.44 log units) above it; measured number inside the range.
By their numbers in this assay, from the lowest: compounds 3, 2 and 1 (each within the scatter of the next, the first and the last beyond it).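

Compound 3 shows that this aromatic carbon, ortho to a methylsulfonyl group, does not need an ether oxygen to keep its number low in this assay: both earlier compounds carry an oxygen-linked group, whereas pyrrolidin-1-yl attaches through nitrogen and brings a five-membered non-aromatic ring. Against ethoxy the change stays within the scatter (a 1.7-fold lower number from compound 2 to compound 3 (0.24 log units; within the scatter)), so compound 2 and compound 3 cannot be ordered, but against benzyloxy it gives the first step in the series to clear the scatter, though only modestly (a 2.5-fold lower number from compound 1 to compound 3 (0.41 log units; beyond the scatter)). Nothing available accounts for either step.

The compounds shown leave open how a six-membered piperidin-1-yl ring, an open-chain dimethylamino group or a plain amine on this carbon would compare with pyrrolidin-1-yl. They also leave open whether morpholin-4-yl, with a second hetero atom in the ring, would fall within the same range.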